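The source may report more compounds than this note shows. Statements on the series, on what has been measured and on what is new or still open speak of the compounds shown alone.

Measured so far:
- compound 1, `Cc1ccccc1N/C(=N\C#N)NC(NC(=O)CCCc1ccccc1)C(C)(C)C`: 25.1 nM
- compound 2, `COc1ccc(CCC(=O)NC(N/C(=N/C#N)Nc2ccccc2C)C(C)(C)C)cc1OC`: 316 nM
- compound 3, `COc1ccc(CCCC(=O)NC(N/C(=N/C#N)Nc2ccccc2C)C(C)(C)C)cc1`: 31.6 nM

In a functional assay on HEK293 cells for antagonist activity at P2X purinoceptor 7 (Rattus norvegicus), read by FLIPR and calcium flux (a lower number here means a stronger inhibitor, a higher number a weaker inhibitor), compound 1 gives the lowest number of the three measured. Compound 4, `COc1ccc(C(=O)NC(N/C(=N/C#N)Nc2ccccc2C)C(C)(C)C)cc1`, differs from it by 4-methoxyphenyl in place of 3-phenylpropyl on a carbonyl carbon. Two of the measured steps bear on this. Adding a single methoxy to the aryl, a 1.3-fold higher number from compound 1 to compound 3 (0.10 log units; within the scatter), changes nothing beyond the scatter. Shortening the chain while adding methoxy groups, a 13-fold higher number from compound 1 to compound 2 (1.10 log units; beyond the scatter), costs a great deal, and a 10-fold lower number from compound 2 to compound 3 (1.00 log units; beyond the scatter) recovers most of it. Compound 4 removes the chain altogether, a larger change than in compound 2, so a sizeable upward step is expected in this assay. For compound 4 the estimate is 600 nM, range 120 nM to 3000 nM, a step of a 24-fold higher number from compound 1 to compound 4 (1.38 log units; beyond the scatter).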

Compound 4, half-maximal inhibitory concentration: 2510 nM
Estimate against measurement, compound 4: 4.2-fold (0.62 log units) below, within the range that was stated.
By their numbers in this assay, from the lowest: compounds 1 and 3 (each within the scatter of the next); then compound 2; then compound 4.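

In this assay, 4-methoxyphenyl on the carbonyl carbon in place of 3-phenylpropyl gives the largest step seen at this position (a 100-fold higher number from compound 1 to compound 4 (2.00 log units; beyond the scatter)). Methoxy alone did not move the number in compound 3, so a chain between the carbonyl and the aryl ring appears to be needed for a low number, at least among these compounds. Nothing at hand gives a cause for the loss. Still open, from the compounds shown here alone, is whether a chain longer than 3-phenylpropyl lowers the number further, and whether an amine on the chain is tolerated.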